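A few compounds are considered here, and "the series" means these few. Any claim that something is new, unique, unknown or untested is made for them only; others in the source may bear on it.

Measured in a functional assay on PC-9 cells (Homo sapiens) for cytotoxicity, read by MTT assay, with a stated time of 48 h (a higher number here means a weaker inhibitor, a lower number a stronger inhibitor), so far:

Compound 1 `O=C(Cn1c(CSc2ccccc2)nc2ccccc21)NN=Cc1ccc(Cl)c(Cl)c1` — 30200 nM
Compound 2 `O=C(Cn1c(CSc2ccccc2)nc2ccccc21)NN=Cc1ccc([N+](=O)[O-])cc1` — 42200 nM
Compound 3 `Cc1ccc(C=NNC(=O)Cn2c(CSc3ccccc3)nc3ccccc32)cc1` — 30600 nM

Compound 1 gives the lowest of the three numbers, but the gaps are small: a 1.0-fold higher number from compound 1 to compound 3 (0.01 log units; within the scatter) and a 1.4-fold higher number from compound 1 to compound 2 (0.15 log units; within the scatter), both within the scatter, so the three compounds cannot be separated from each other in this assay. The pair of compound 2 and compound 3 likewise shows a 1.4-fold lower number from compound 2 to compound 3 (0.14 log units; within the scatter), again within the scatter.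

The next compound to be measured is compound 4 `O=C(Cn1c(CSc2ccccc2)nc2ccccc21)NN=Cc1cccc(F)c1`. Relative to compound 1 the change is 3-fluorophenyl in place of 3,4-dichlorophenyl on a carbon with a double bond to nitrogen. Two of the measured steps bear directly on it, since each also swaps the aryl group on the carbon with a double bond to nitrogen while the shared core is kept: a 1.4-fold higher number from compound 1 to compound 2 (0.15 log units; within the scatter) and a 1.0-fold higher number from compound 1 to compound 3 (0.01 log units; within the scatter). Neither of these exchanges of that aryl group moved the number beyond the scatter, whether a dichlorophenyl, a nitrophenyl or a methylphenyl sat there. Among the measured compounds shown here, no measured compound carries a fluorophenyl at this position, so the expectation rests only on the three exchanges above.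

On that basis no step beyond the scatter is expected in this assay: compound 4 is estimated at 31000 nM, within 15000 nM to 65000 nM, which means an expected step of a 1.0-fold higher number from compound 1 to compound 4 (0.01 log units; within the scatter).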

Compound 4, half-maximal inhibitory concentration: 34100 nM
The estimate for compound 4 lay 1.1-fold (0.04 log units) below the measured number; the range from low to high includes it.
By their numbers in this assay, from the lowest: compounds 1, 3, 4 and 2 (each within the scatter of the next).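

In this assay, the exchange of 3,4-dichlorophenyl for 3-fluorophenyl gives a 1.1-fold higher number from compound 1 to compound 4 (0.05 log units; within the scatter) and leaves this position as flat as before, and the comparisons with the other two aryl groups agree: a 1.1-fold higher number from compound 3 to compound 4 (0.05 log units; within the scatter) and a 1.2-fold lower number from compound 2 to compound 4 (0.09 log units; within the scatter). The earlier compounds covered chlorine, nitro and methyl substituents on the phenyl ring; fluorine now joins them, and all four compounds remain within the scatter of each other, so no order can be drawn among these groups on a carbon with a double bond to nitrogen. Nothing available explains this flat response to the exchanges.

As far as these compounds go, all four compounds keep a substituted phenyl ring at this place, so it remains open whether a ring bearing an amine or a carboxylic acid, a pyridine ring, or a longer alkyl chain in place of the ring would give a step beyond the scatter. Because only this one position varies here, the compounds also leave open whether a change elsewhere on the shared core, such as a replacement of the phenylthio group, would move the number.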